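The source may report more compounds than this note shows. Statements on the series, on what has been measured and on what is new or still open speak of the compounds shown alone.

Measured compounds in a functional assay on MCF7 cells (Homo sapiens) for inhibition, read by CCK-8 assay, with a stated time of 48 h; a lower number here means a stronger inhibitor, a higher number a weaker inhibitor:

compound 1, `COc1cc(-c2ccnc3cc(-c4ccc(C)cc4)nn23)cc(OC)c1OC`: 47 nM
compound 2, `COc1cc(-c2ccnc3cc(-c4ccc(C(F)(F)F)cc4)nn23)cc(OC)c1OC`: 2440 nM

Compound 1 holds the lowest of the two numbers; its nearest neighbour is compound 2, which gives a much higher number, as seen in the step of a 52-fold higher number from compound 1 to compound 2 (1.72 log units; beyond the scatter), brought about by trifluoromethyl in place of methyl on an aromatic carbon. Compound 3, `COc1cc(-c2ccnc3cc(-c4ccc5ccn(C)c5c4)nn23)cc(OC)c1OC`, has not yet been measured in this assay. It differs from compound 1 as follows: 1-methyl-1H-indol-6-yl in place of 4-methylphenyl on an aromatic carbon. Among the compounds with values here, the only measured step, a 52-fold higher number from compound 1 to compound 2 (1.72 log units; beyond the scatter), concerns a change at the same 4-methylphenyl group and was large; it shows that this group is sensitive to alteration, but a swap of the whole ring for 1-methyl-1H-indol-6-yl is not the same kind of change, so it serves only as a loose guide. The expectation for compound 3 is a step of a 3.2-fold higher number from compound 1 to compound 3 (0.50 log units; beyond the scatter), towards a weaker inhibitor, with wide uncertainty. The estimate for compound 3 in this assay is 150 nM, with a range from 30 nM to 800 nM.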

Compound 3, half-maximal inhibitory concentration: 74 nM
The estimate for compound 3 lay 2.0-fold (0.31 log units) above the measured number; the range from low to high includes it.
By their numbers in this assay, from the lowest: compounds 1 and 3 (each within the scatter of the next); then compound 2.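

In this assay, the aromatic carbon on the five-membered aromatic ring with 2 nitrogen accepts an exchange of the whole group: 1-methyl-1H-indol-6-yl in place of 4-methylphenyl gives a 1.6-fold higher number from compound 1 to compound 3 (0.20 log units; within the scatter). A group of 10 heavy atoms with a second aromatic ring and a nitrogen therefore stands level with one of 7 heavy atoms, so the sensitivity seen with trifluoromethyl does not extend to every change at this group; the replacement of 4-(trifluoromethyl)phenyl gives a 33-fold lower number from compound 2 to compound 3 (1.52 log units; beyond the scatter), which leaves compound 2 apart from the other two. No measurement at hand bears on the reason for either step.

The compounds shown leave open whether the methyl on the indole nitrogen contributes anything, as the unsubstituted indole and a longer chain on that nitrogen do not appear among them. They also leave open how a methoxy group, a chlorine, an amine or a carboxylic acid would behave in place of the methyl of 4-methylphenyl, so the limits of what this position accepts remain undefined.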